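Clearance notes: ring swap on the aryl substituent

The compounds below may be only part of what the source reports. "The series", "measured", "known", "first", "only" and "open" are said of these compounds alone.

Compound 1 `CC(=O)N[C@@H]1CCC[C@H](C(=O)Nc2cc(-c3cnc4n3CCCC4)c(Cl)cn2)C1` is the reference point of this small set; in an ADME assay on cells (Hepatocyte, Rattus norvegicus) for metabolic stability, using equilibrium dialysis (on this read-out lower numbers stand for slow clearance and higher numbers for fast clearance), compound 1 gives 12 uL/min. Compound 2 `CC(=O)N[C@@H]1CCC[C@H](C(=O)Nc2cc(-c3cnc4n3CCC4)c(Cl)cn2)C1` carries a five-membered non-aromatic ring in place of the six-membered one, and in this assay compound 2 gives 19 uL/min. Going by the values given here, the only step so far, a 1.6-fold higher number from compound 1 to compound 2 (0.20 log units; within the scatter), leaves compound 2 and compound 1 within the scatter of each other, so compound 2 stands at one end of two numbers that cannot be told apart.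

Compound 3 `CC(=O)N[C@@H]1CCC[C@H](C(=O)Nc2cc(-c3cnn4c3COCC4)c(Cl)cn2)C1` differs from compound 2 by a group of 9 heavy atoms (6 carbon, 2 nitrogen, 1 oxygen; one five-membered aromatic ring with 2 hetero atoms, one six-membered non-aromatic ring with 2 hetero atoms) in place of a group of 8 heavy atoms (6 carbon, 2 nitrogen; one five-membered non-aromatic ring with 1 hetero atom, one five-membered aromatic ring with 2 hetero atoms), on an aromatic carbon. The entering group returns to a six-membered non-aromatic ring, now with 2 hetero atoms, one of them oxygen, and gains one hydrogen-bond acceptor; the place on the shared core, ortho to a chloro group and opposite the ring nitrogen, is unchanged.

Among the compounds with values here, the one step that bears on this, a 1.6-fold higher number from compound 1 to compound 2 (0.20 log units; within the scatter), stayed within the scatter when the ring size changed, so no step beyond the scatter is expected here either. The expected step of a 1.4-fold lower number from compound 2 to compound 3 (0.13 log units; within the scatter) is a modest move back toward compound 1. For compound 3 in this assay the estimate is 14 uL/min, with a range of 6 uL/min to 32 uL/min.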

Compound 3, intrinsic clearance in a liver preparation (reported as CLH), per the amount of preparation that the assay uses: 18 uL/min
Beside the measured number, compound 3's estimate is 1.3-fold (0.11 log units) below it; the range from low to high includes it.
By their numbers in this assay, from the lowest: compounds 1, 3 and 2 (each within the scatter of the next).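

In this assay, the group with a six-membered non-aromatic ring holding 2 hetero atoms, one of them oxygen, and 3 hydrogen-bond acceptors in place of 2, gives a 1.1-fold lower number from compound 2 to compound 3 (0.02 log units; within the scatter), so this exchange at the aromatic carbon ortho to a chloro group stays within the scatter. Set against the group of compound 1, which has the same count of 9 heavy atoms but 7 carbon and no oxygen, the new group gives a 1.5-fold higher number from compound 1 to compound 3 (0.18 log units; within the scatter), which is also within the scatter, so all three groups at this place now form one band that the assay cannot separate. No measurement available here offers an explanation for this flat result.

Whether any group at this place can move the clearance number beyond the scatter remains open, since all three groups shown pair a five-membered aromatic ring with 2 hetero atoms with a second, non-aromatic ring. An amine or a carboxylic acid on that ring system, or a nitrile in place of the chloro group, would test this position and its surroundings more severely than these ring exchanges do.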